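Dialkylamino to Ethylamino: What Compound 4 May Show

The source may report more compounds than this note shows. Statements on the series, on what has been measured and on what is new or still open speak of the compounds shown alone.

Compound 2 `CC(C)N(c1nc2c(ncn2-c2ccccc2)c(=O)n1-c1ccccc1)C(C)C` gives the highest of the three numbers in a functional assay on KB cells (Homo sapiens) for cytotoxicity, read by MTT assay, with a stated time of 72 h (a higher number here means a weaker inhibitor, a lower number a stronger inhibitor), at 53500 nM. Compound 1 `CCCCN(CCCC)c1nc2c(ncn2-c2ccccc2)c(=O)n1-c1ccccc1` gives 9500 nM in this assay, and compound 3 `CCCCCN(CCCCC)c1nc2c(ncn2-c2ccccc2)c(=O)n1-c1ccc(Cl)cc1` gives 10600 nM. For the measured compounds named here, the one step that bears on the new change, a 5.6-fold higher number from compound 1 to compound 2 (0.75 log units; beyond the scatter), shows that exchanging one dialkylamino group for another shifts the number by a modest amount. Going by the values given here, compound 4 `CCNc1nc2c(ncn2-c2ccccc2)c(=O)n1-c1ccccc1` carries ethylamino in place of diisopropylamino on an aromatic carbon, a smaller group with no direct precedent among the measured compounds. Since compound 1 with its dibutylamino group reads 9500 nM, a move back toward that region seems plausible, though the direction remains uncertain. Compound 4 is therefore estimated at 15000 nM, within 4000 nM to 60000 nM, an expected 3.6-fold lower number from compound 2 to compound 4 (0.55 log units; beyond the scatter).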

Compound 4, half-maximal inhibitory concentration: > 100000 nM
Compound 4: a limit, no number; the forecaster's own chance of this, stated with the estimate: 10%; at least 6.6-fold (0.82 log units) between middle value and limit.
By their numbers in this assay, from the lowest: compounds 1 and 3 (each within the scatter of the next); then compound 2. At a limit, above all of these: compound 4.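

In this assay compound 4 gives > 100000 nM, a limit and not a number. Ethylamino in place of dibutylamino gives an at least 10-fold higher number from compound 1 to compound 4 (1.02 log units; beyond the scatter), the first large step seen at this position on the shared core. Against diisopropylamino the reading is less firm, with an at least 1.8-fold higher number from compound 2 to compound 4 (0.27 log units; that floor lies within the scatter), so the true size of this step remains unknown.

The compounds shown leave open whether the chain length or the change from a dialkylamino to a monoalkylamino group matters more. A diethylamino group or a butylamino group at this position could separate the two.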